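This account rests on a few compounds, and the source may have more. Where it says the series, first, only, none or still open, it means among the compounds named here.

Compounds measured in a functional assay on Huh-7 cells (Homo sapiens) for inhibition, read by sulforhodamine B assay, with a stated time of 72 h (on this read-out higher numbers stand for weaker inhibition and lower numbers for stronger inhibition), so far:
compound 1 `O=C(/C=C/c1cn(-c2ccccc2)nc1-c1ccncc1)c1cc[nH]c1`, 28800 nM
compound 2 `O=C(/C=C/c1cn(-c2ccccc2)nc1-c1ccncc1)c1ccccc1`, 1800 nM

Compound 2 holds the lowest of the two numbers; its nearest neighbour is compound 1, and the step of a 16-fold lower number from compound 1 to compound 2 (1.20 log units; beyond the scatter) is large and beyond the scatter. Compound 3 `COc1ccc(OC)c(C(=O)/C=C/c2cn(-c3ccccc3)nc2-c2ccncc2)c1` differs from compound 2 by 2,5-dimethoxyphenyl in place of phenyl on a carbonyl carbon. For the measured compounds named here, the single measured step touches the same carbonyl carbon, but it exchanges one aryl group for another ring type, whereas here the phenyl stays and only gains two methoxy groups. That step shows this position can shift this assay strongly; it gives no direction for the present change. The step from compound 2 to compound 3 is therefore expected to stay within the scatter, a 1.2-fold lower number from compound 2 to compound 3 (0.08 log units; within the scatter). Compound 3 is estimated at 1500 nM in this assay, with a range of 400 nM to 6000 nM.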

Compound 3, half-maximal inhibitory concentration: 1700 nM
Estimate against measurement, compound 3: 1.1-fold (0.05 log units) below; the measured number falls inside the stated range.
By their numbers in this assay, from the lowest: compounds 3 and 2 (each within the scatter of the next); then compound 1.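

In this assay, 2,5-dimethoxyphenyl on the carbonyl carbon gives a number indistinguishable from that of phenyl (a 1.1-fold lower number from compound 2 to compound 3 (0.02 log units; within the scatter)), so this position takes the added oxygen atoms and the two hydrogen-bond acceptors with no readable change. The large gap to the 1H-pyrrol-3-yl compound also holds for the substituted ring (a 17-fold lower number from compound 1 to compound 3 (1.23 log units; beyond the scatter)), so it is not confined to plain phenyl. No supporting data bear on the reason for either step.

The compounds shown leave open whether a single methoxy group would behave like the pair, as the two enter together here. Also open, from the compounds shown here alone, is how this assay responds to an amine or a carboxylic acid on the phenyl ring, or to a longer alkyl chain in place of the ring on the carbonyl carbon.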